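Working notes: 2-cyanophenyl to 2-ethylphenyl

The source may report more compounds than this note shows. Statements on the series, on what has been measured and on what is new or still open speak of the compounds shown alone.

In an ADME assay (liver) for metabolic stability, with Liver microsome (Homo sapiens) as the target, read by LC-MS, using microsomes, with a stated time of 30 min, tested at 4 uM (a lower number here means that less of the compound is left, a higher number that more of the compound is left), compound 3 `Cc1nc(N2CCN(C)CC2)c2nc(-c3ccccc3C#N)n(C3CCOCC3)c2n1` gives 20% as the starting point for this step. Compound 2 `Cc1nc(N2CCN(C)CC2)c2nc(-c3cccc(Cl)c3)n(C3CCOCC3)c2n1` gives 25% and lies within the scatter of compound 3. Compound 1 `Cc1nc(N2CCN(C)CC2)c2nc(-c3ccccc3Cl)n(C3CC3)c2n1` gives 31% and stands higher than compound 3 by more than the scatter.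

The change to compound 4 `CCc1ccccc1-c1nc2c(N3CCN(C)CC3)nc(C)nc2n1C1CCOCC1` puts ethyl in place of cyano on an aromatic carbon, ortho to a large group, and reads ethyl in place of cyano on an aromatic carbon in counted terms.

Going by the values given here, one measured step bears on it, at the same aromatic group. Among the compounds with values here, the swap of 3-chlorophenyl for 2-cyanophenyl gave a number 5 percentage points lower from compound 2 to compound 3 (within the scatter) and is the only comparison that differs in one place. Compound 1 differs from compound 3 in more than one place and isolates nothing here. Within the data shown here, no measured compound carries ethyl, so the data give no direct reading of this group.

No step beyond the scatter is therefore expected in this assay and only a slight downward lean is allowed for. The estimated change is a number 4 percentage points lower from compound 3 to compound 4 (within the scatter) and remains an expectation until measured. Compound 4 is estimated at 16% with an expected range of 6% to 30% for this read-out.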

Compound 4, percent of the compound remaining: 33%
Estimate against measurement, compound 4: 17 percentage points below; the whole stated range lies below it.
By their numbers in this assay, from the lowest: compounds 3, 2, 1 and 4 (each within the scatter of the next, the first and the last beyond it).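

In this assay, ethyl in place of cyano on an aromatic carbon, ortho to a large group, gives a number 13 percentage points higher from compound 3 to compound 4 (beyond the scatter) and is the only step shown at this aromatic group that passes beyond the scatter. The other step that reaches compound 4, a number 8 percentage points higher from compound 2 to compound 4 (within the scatter), stays within the scatter, so the reading separates 2-ethylphenyl from 2-cyanophenyl but not from 3-chlorophenyl, a distinction the earlier swap between 3-chlorophenyl and 2-cyanophenyl could not show. No supporting measurement accompanies these numbers, and the reason for the step remains unknown.

The compounds shown leave open whether the step follows ethyl itself or the departure of the nitrile, a question that methyl, a longer chain such as propyl, or methoxy on the same aromatic carbon would help to settle. They also leave open whether ethyl in place of cyano reads the same way when the cyclopropyl group of compound 1 stands on the shared core.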